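Methoxy-to-cyano anilines: chain extension on the amide

The source may hold more compounds than are shown below. What is called first, only, known or untested is meant among the compounds shown, and "the series" means these compounds.

Three members of the series have been measured in a functional assay on A549 cells (Homo sapiens) for inhibition, read by MTT assay, with a stated time of 72 h; on this read-out lower numbers stand for stronger inhibition and higher numbers for weaker inhibition. Compound 1 `C/C=C/C(=O)Nc1cccc(Oc2nc(Nc3cccc(OC)c3)nc3ccsc23)c1` gives 10500 nM. Compound 2 `CC/C=C/C(=O)Nc1cccc(Oc2nc(Nc3cccc(OC)c3)nc3ccsc23)c1` gives 19600 nM. Compound 3 `C/C=C/C(=O)Nc1cccc(Oc2nc(Nc3cccc(C#N)c3)nc3ccsc23)c1` gives 11300 nM. On these three numbers compound 3 stands second highest; its nearest neighbour is compound 1 and its furthest compound 2, yet both a 1.1-fold higher number from compound 1 to compound 3 (0.03 log units; within the scatter) and the gap to compound 2 lie within the scatter, so no order among the three can be claimed.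

Compound 4 `CC/C=C/C(=O)Nc1cccc(Oc2nc(Nc3cccc(C#N)c3)nc3ccsc23)c1` is not yet measured. It differs from compound 3 by methyl in place of hydrogen on a saturated chain carbon bound to a double-bonded chain carbon. Going by the values given here, the one measured step that bears on this change is the same alteration made on the methoxy-bearing pair, where a 1.9-fold higher number from compound 1 to compound 2 (0.27 log units; within the scatter). Among the compounds with values here, that step stayed within the scatter, and nothing among the measured compounds suggests the cyano-bearing pair should behave differently. The expectation for compound 4 in this assay is therefore a step of about the same size and direction, a 1.7-fold higher number from compound 3 to compound 4 (0.23 log units; within the scatter), which is expected to remain within the scatter. The estimate for compound 4 is accordingly 19000 nM, with a range from 9000 nM to 42000 nM.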

Compound 4, half-maximal inhibitory concentration: 14900 nM
Compound 4: middle estimate off by 1.3-fold (0.11 log units), on the high side; the measured number falls inside the stated range.
By their numbers in this assay, from the lowest: compounds 1, 3, 4 and 2 (each within the scatter of the next).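

In this assay, the change from (prop-1-en-1-yl)carbonyl to (but-1-en-1-yl)carbonyl can now be read on the cyano-bearing pair as well, as a 1.3-fold higher number from compound 3 to compound 4 (0.12 log units; within the scatter), and the readings on the two cores agree: the same change on two cores in this assay, a 1.9-fold higher number (0.27 log units; within the scatter) from compound 1 to compound 2 and a 1.3-fold higher number (0.12 log units; within the scatter) from compound 3 to compound 4, 1.4-fold (0.15 log units) apart, within the scatter of two such steps
The exchange of methoxy for cyano on an aromatic carbon can likewise be read on the but-1-en-1-yl amides, as a 1.3-fold lower number from compound 2 to compound 4 (0.12 log units; within the scatter), and it agrees with the reading on the prop-1-en-1-yl amides: the same change on two cores in this assay, a 1.1-fold higher number (0.03 log units; within the scatter) from compound 1 to compound 3 and a 1.3-fold lower number (0.12 log units; within the scatter) from compound 2 to compound 4, 1.4-fold (0.15 log units) apart, within the scatter of two such steps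
Each change has thus been read on two partners, and neither step on either partner leaves the scatter, so compound 1, compound 2, compound 3 and compound 4 give no sign that the two changes depend on each other.

Because every step here lies within the scatter, these compounds do not show whether the saturated chain carbon bound to a double-bonded chain carbon can shift the number at all. On these data alone, that remains open for a longer chain or an amine at that carbon, and for a carboxylic acid in place of cyano on the aromatic carbon.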